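The source may hold more compounds than are shown below. What is called first, only, known or untested is meant among the compounds shown, and "the series" means these compounds.

Of the compounds shown here, three of a shared core have been measured in a functional assay on MCF7 cells (Homo sapiens) for inhibition, read by MTT assay, with a stated time of 72 h; a lower number here means a stronger inhibitor of growth, a higher number a weaker inhibitor of growth. Compound 1 `O=S(=O)(NCCCNCc1ccc(Cl)cc1)c1cc(C(F)(F)F)cc(C(F)(F)F)c1` gives 2400 nM, compound 2 `CC(C)(C)c1ccc(CNCCCNS(=O)(=O)c2cc(C(F)(F)F)cc(C(F)(F)F)c2)cc1` gives 2100 nM, and compound 3 `O=S(=O)(NCCCNCc1ccc(C(F)(F)F)cc1)c1cc(C(F)(F)F)cc(C(F)(F)F)c1` gives 1400 nM. The steps between them are small: a 1.1-fold lower number from compound 1 to compound 2 (0.06 log units; within the scatter), a 1.7-fold lower number from compound 1 to compound 3 (0.23 log units; within the scatter) and a 1.5-fold lower number from compound 2 to compound 3 (0.18 log units; within the scatter). Compound 3 has the lowest of the three numbers, yet its gaps to compound 2 and to compound 1 both lie within the scatter, so no order among the three can be claimed.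

Compound 4 `O=S(=O)(NCCCNCc1ccc(Br)cc1)c1cc(C(F)(F)F)cc(C(F)(F)F)c1` differs from compound 3 in one place: bromo in place of trifluoromethyl on an aromatic carbon. Within the data shown here, the step that bears most directly on it is the one between compound 1 and compound 3, where a chloro group stood on the same aromatic carbon, and it was within the scatter; the exchanges for tert-butyl in compound 2 were likewise within the scatter. Every change tried at this position has therefore left the number in this assay essentially unchanged. Compound 4 is accordingly expected to show a 1.4-fold higher number from compound 3 to compound 4 (0.13 log units; within the scatter), a step that stays within the scatter. The estimate for compound 4 in this assay is 1900 nM, with a range from 900 nM to 4000 nM.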

Compound 4, concentration for 50% growth inhibition: 1900 nM
Compound 4: middle estimate and measured number agree at the digits printed; the range from low to high includes it.
By their numbers in this assay, from the lowest: compounds 3, 4, 2 and 1 (each within the scatter of the next).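

In this assay, the exchange of trifluoromethyl for bromo gives a 1.4-fold higher number from compound 3 to compound 4 (0.13 log units; within the scatter), the exchange of tert-butyl for bromo gives a 1.1-fold lower number from compound 2 to compound 4 (0.04 log units; within the scatter), and the exchange of chloro for bromo gives a 1.3-fold lower number from compound 1 to compound 4 (0.10 log units; within the scatter). With bromo as a fourth group, every pair at this aromatic carbon lies within the scatter, including the pair in which 1 heavy atom of bromine replaces the 4 heavy atoms of trifluoromethyl, so this assay still gives no order among the four compounds. Nothing measured here accounts for this flat result.

The compounds shown leave open whether a group of a different kind on this carbon, such as an amine, a hydroxyl or a carboxylic acid, would carry the number beyond the scatter. Among these compounds, they also leave open whether changes elsewhere in the shared core, such as a longer chain in place of the present one, would have a larger effect in this assay than any exchange at this position so far.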